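Quaternary ammonium amides on the shared core

A few compounds are considered here, and "the series" means these few. Any claim that something is new, unique, unknown or untested is made for them only; others in the source may bear on it.

Compound 1, `Cc1cc(C)c2cccc(OCc3c(Cl)ccc(S(=O)(=O)NC4(C(=O)N5CCN(C(=O)CCC[N+](C)(C)C)CC5)CCCC4)c3Cl)c2n1`: in an assay on isolated protein for binding affinity to B1 bradykinin receptor (Homo sapiens) (a lower number here means a stronger inhibitor, a higher number a weaker inhibitor), compound 1 gives < 10000 nM, which is a limit of the assay and not a number.
Compound 2, `Cc1cc(C)c2cccc(OCc3c(Cl)ccc(S(=O)(=O)NC4(C(=O)N5CCN(C(=O)[C@@H](N)CC[N+](C)(C)C)CC5)CCCC4)c3Cl)c2n1`: in this assay compound 2 gives < 10000 nM, again only a limit.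
Compound 3, `Cc1cc(C)c2cccc(OCc3c(Cl)ccc(S(=O)(=O)NC4(C(=O)N5CCN(C(=O)CCCC[N+](C)(C)C)CC5)CCCC4)c3Cl)c2n1`: in this assay compound 3 gives < 10000 nM, also only a limit.

All three values sit at the same limit, (the limit of < 10000 nM in this assay, at which 3 of the 3 values shown sit), so none of the steps among them can be read: a step that the two limits leave unreadable from compound 1 to compound 2, a step that the two limits leave unreadable from compound 1 to compound 3 and a step that the two limits leave unreadable from compound 2 to compound 3. The change from compound 1 to compound 2 is amino in place of hydrogen on a saturated chain carbon bound to a carbonyl carbon and a saturated chain carbon. The cores of compound 1 and compound 3 differ by a group of 5 heavy atoms (4 carbon, 1 nitrogen; no ring) in place of a group of 4 heavy atoms (3 carbon, 1 nitrogen; no ring), on a saturated chain carbon, three bonds along the chain from a carbonyl carbon.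

Compound 4, `Cc1cc(C)c2cccc(OCc3c(Cl)ccc(S(=O)(=O)NC4(C(=O)N5CCN(C(=O)[C@@H](N)CCC[N+](C)(C)C)CC5)CCCC4)c3Cl)c2n1`, is not yet measured in this assay. It differs from compound 3 by amino in place of hydrogen on a saturated chain carbon bound to a carbonyl carbon and a saturated chain carbon, the same change as from compound 1 to compound 2, at a place described in the same words. That earlier step has no readable size. For compound 4 the expected step is a step that the limit leaves unreadable from compound 3 to compound 4, resting on nothing more than the unreadable a step that the two limits leave unreadable from compound 1 to compound 2. Compound 4 is estimated at 1000 nM, between 30 nM and 9000 nM, and it may well again come back as only a limit.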

Compound 4, inhibition constant: < 10000 nM
Compound 4: a limit, no number (the forecaster's own chance of this, stated with the estimate: 60%); the middle value is on the limit's open side.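

In this assay compound 4 gives < 10000 nM, again a limit and not a number. Its steps to compound 1, compound 2 and compound 3 therefore cannot be read: the limit of < 10000 nM in this assay, at which 4 of the 4 values shown sit.

The compounds shown leave open whether amino in place of hydrogen, or the change in chain length, has any effect in this assay.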